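This account rests on a few compounds, and the source may have more. Where it says the series, first, only, none or still open, it means among the compounds named here.

Compound 1, `C=C[C@@](C)(/C=C/c1ccc(Nc2ccc(OC)cc2)cc1)CCC=C(C)C`, gives in an ADME assay on HEK293 cells (Homo sapiens) for cytotoxicity, with a stated time of 72 h (on this read-out lower numbers stand for an effect already at smaller amounts and higher numbers for an effect only at larger amounts of compound), only a limit of the assay, > 36600 nM. Compound 2, `C=C[C@@](C)(/C=C/c1ccc(Nc2ccc(OC)c(F)c2)cc1)CCC=C(C)C`, gives in this assay likewise a limit, > 36600 nM. Compound 3, `C=C[C@@](C)(/C=C/c1ccc(-c2ccccc2)cc1)CCC=C(C)C`, also gives in this assay a limit, > 36600 nM.

All three measured compounds thus sit at the same point, which is described by the limit of > 36600 nM in this assay, at which 3 of the 3 values shown sit. The change from compound 1 to compound 2, (fluoro in place of hydrogen on an aromatic carbon), made the step that the two limits leave unreadable from compound 1 to compound 2. The change of core from compound 1 to compound 3, (phenyl in place of (4-methoxyphenyl)amino on an aromatic carbon), made the step that the two limits leave unreadable from compound 1 to compound 3.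

Compound 4, `C=C[C@@](C)(/C=C/c1ccc(-c2ccc(F)cc2)cc1)CCC=C(C)C`, is not yet measured. It differs from compound 3 by fluoro in place of hydrogen on an aromatic carbon, the same kind of change as from compound 1 to compound 2, though the place differs: in compound 2 the fluoro sits ortho to a methoxy group and meta to a large group, in compound 4 para to a large group. Since compound 3 stands at the limit, compound 4 is expected to show the step that the limit leaves unreadable from compound 3 to compound 4, most likely again only a limit. The estimate for compound 4 is 40000 nM, between 20000 nM and 80000 nM.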

Compound 4, half-maximal effective concentration: > 36600 nM
Compound 4 gave a limit, no number; the forecaster's own chance of this, stated with the estimate: 85%; the middle value lies beyond the limit too.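

Compound 4 gives in this assay only a limit, > 36600 nM, so its steps from compound 3 and from compound 1 cannot be read. All four compounds now sit at one point: the limit of > 36600 nM in this assay, at which 4 of the 4 values shown sit. The compounds shown leave open at what concentration each would show cytotoxicity, and whether any of these changes alters it.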